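Chloro for Methyl: A Step Awaiting Its Measurement

A few compounds are considered here, and "the series" means these few. Any claim that something is new, unique, unknown or untested is made for them only; others in the source may bear on it.

Compound 3 `Cc1ccc(-c2cc(C3=CC(=O)C=CC3=O)n(-c3ccc(S(N)(=O)=O)cc3)n2)cc1` was tested in a functional assay on cells (Melanoma cell, Homo sapiens) for cytotoxicity, read by sulforhodamine B assay, with a stated time of 48 h (on this read-out lower numbers stand for stronger inhibition of growth and higher numbers for weaker inhibition of growth), where compound 3 gives 69400 nM. On that read-out compound 3 stands level with compound 2 `O=C1C=CC(=O)C(c2cc(-c3ccc(Cl)cc3)nn2-c2ccccc2)=C1`, which in this assay gives 69400 nM; the two numbers do not differ at the digits shown, so the pair sits within the scatter and no order can be drawn between them. Together they are the highest of the three values. The furthest from compound 3 is compound 1 `NS(=O)(=O)c1ccc(-n2nc(-c3ccc(Cl)cc3)cc2-c2cc(O)ccc2O)cc1`, which in this assay gives 14600 nM, a gap that lies beyond the scatter.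

The next compound, compound 4 `NS(=O)(=O)c1ccc(-n2nc(-c3ccc(Cl)cc3)cc2C2=CC(=O)C=CC2=O)cc1`, has not yet been measured. It differs from compound 3 in one place: chloro in place of methyl on an aromatic carbon. For the measured compounds named here, no pair of measured compounds shows this same change on its own, so its effect is not known from the data.

Compound 2 gives 69400 nM and compound 3 gives 69400 nM although they differ in more than one place, which suggests that a small change on the six-membered aromatic ring of carbon only may move the number little. The step from compound 3 to compound 4 is therefore expected to be a 1.3-fold lower number from compound 3 to compound 4 (0.10 log units; within the scatter), none beyond the scatter, in either direction. Compound 4 is expected to give 55000 nM in this assay, within a range from 20000 nM to 150000 nM.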

Compound 4, concentration for 50% growth inhibition: 26700 nM
Estimate against measurement, compound 4: 2.1-fold (0.31 log units) above, within the range that was stated.
By their numbers in this assay, from the lowest: compounds 1 and 4 (each within the scatter of the next); then compounds 2 and 3 (each within the scatter of the next).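

In this assay, for the compounds shown here, the change from 4-methylphenyl to 4-chlorophenyl brings a 2.6-fold lower number from compound 3 to compound 4 (0.41 log units; beyond the scatter) and so shows, as no measured pair could before, that this place on the ring, para to a large group, responds to chloro in place of methyl. Sulfamoyl in place of hydrogen on an aromatic carbon, a change in another part of the molecule, brings a 2.6-fold lower number from compound 2 to compound 4 (0.41 log units; beyond the scatter) and so gives a step of the same size. The exchange of the six-membered aromatic ring of carbon only for the six-membered non-aromatic ring of carbon only brings a 1.8-fold higher number from compound 1 to compound 4 (0.26 log units; within the scatter) and stays within the scatter, so no order can be drawn between these two compounds on this read-out.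

The compounds shown leave open how a fluoro group, a methoxy group or an amine would stand at this same place against chloro and methyl. Nothing measured on these compounds gives a reason for any of these steps.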